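This account rests on a few compounds, and the source may have more. Where it says the series, first, only, none or still open, it means among the compounds named here.

Measured so far:
compound 1 `C[C@@H]1CN(c2ncc(OCc3ccc(S(C)(=O)=O)cc3)cn2)CCN1C(=O)OC(C)(C)C` — > 30000 nM
compound 2 `C[C@@H]1CN(C(=O)OC(C)(C)C)CCN1c1ncc(OCC2CCN(S(C)(=O)=O)CC2)cn1` — 78 nM
compound 3 `C[C@@H]1CN(C(=O)OC(C)(C)C)CCN1c1ncc(OCc2ccc(S(=O)(=O)N(C)C)cc2)cn1` — 264 nM

In a functional assay for agonist activity at Glucose-dependent insulinotropic receptor (Mus musculus), read by HTRF and cAMP accumulation, with a stated time of 45 min (a lower number here means that less compound is needed, a higher number that more compound is needed for the effect), compound 1 reaches only the limit of the assay, > 30000 nM, a limit and not a number (the limit of > 30000 nM in this assay, at which 1 of the 3 values shown sits). Of the two numbers, compound 3 stands highest, with compound 2 nearest and giving the lower number in this assay; that gap lies beyond the scatter.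

Compound 4 `C[C@@H]1CN(C(=O)OC(C)(C)C)CCN1c1ncc(OCc2ccc(-n3cnnn3)cc2)cn1` is not yet measured. It differs from compound 3 in one place: 1H-tetrazol-1-yl in place of dimethylsulfamoyl on an aromatic carbon. No step between measured compounds covers this kind of exchange, so nothing shown sets its size. The expectation is a modest loss in this assay, roughly a 1.9-fold higher number from compound 3 to compound 4 (0.28 log units; within the scatter), with a wide range. Compound 4 is therefore estimated at 500 nM, between 100 nM and 5000 nM.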

Compound 4, half-maximal effective concentration: 33 nM
Compound 4: middle estimate off by 15-fold (1.18 log units), on the high side; the whole stated range lies above it.
By their numbers in this assay, from the lowest: compound 4; then compound 2; then compound 3. At a limit, above all of these: compound 1.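

On the aromatic carbon para to a large group, a sulfonyl-containing substituent is not needed for activity in this assay: 1H-tetrazol-1-yl in place of dimethylsulfamoyl gives an 8.0-fold lower number from compound 3 to compound 4 (0.90 log units; beyond the scatter). The phenyl series now also surpasses the sulfonylated piperidine, with 4-(1H-tetrazol-1-yl)phenyl in place of 1-(methylsulfonyl)piperidin-4-yl giving a 2.4-fold lower number from compound 2 to compound 4 (0.37 log units; beyond the scatter). No measurement shown accounts for either gain. Going by these compounds, whether the tetrazole itself is required remains open, since no imidazole, triazole or carboxylic acid occupies that position here. The tert-butyl carbamate also stays constant throughout.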